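Moving the Fluorine Around the Benzyl Ring

The compounds below may be only part of what the source reports. "The series", "measured", "known", "first", "only" and "open" are said of these compounds alone.

Compound 1 `O=C(N[C@H]1CCN(Cc2ccc(Cl)c(Cl)c2)C1)c1ccc(-c2cccs2)cc1`: 5000 nM
Compound 2 `O=C(N[C@H]1CCN(Cc2ccccc2F)C1)c1ccc(-c2cccs2)cc1`: 6900 nM

In an assay on frontal cortex for displacement of a labelled ligand from Adrenergic receptor alpha-1 (Rattus norvegicus) (a higher number here means a weaker inhibitor, a lower number a stronger inhibitor), compound 2 gives 6900 nM, and the step of a 1.4-fold higher number from compound 1 to compound 2 (0.14 log units; within the scatter) lies within the scatter, so nothing separates compound 2 from compound 1 here. Compound 3 `O=C(N[C@H]1CCN(Cc2ccc(F)cc2)C1)c1ccc(-c2cccs2)cc1` differs from compound 2 by 4-fluorophenyl in place of 2-fluorophenyl on a saturated chain carbon bound to an amine nitrogen in a ring. Among the compounds with values here, the only measured step exchanges the whole aryl group at that place and stays within the scatter; no measured pair moves a fluorine around the ring. Compound 3 is therefore expected to give about 6000 nM, between 2500 nM and 15000 nM. The step of a 1.2-fold lower number from compound 2 to compound 3 (0.06 log units; within the scatter) is expected to remain within the scatter.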

Compound 3, inhibition constant: 420 nM
For compound 3 the middle estimate is 14-fold (1.15 log units) above the measured one; measured number below the stated range.
By their numbers in this assay, from the lowest: compound 3; then compounds 1 and 2 (each within the scatter of the next).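

In this assay the place of the fluorine matters, not just which aryl group is present: 2-fluorobenzyl to 4-fluorobenzyl, with the same atoms, gives a 16-fold lower number from compound 2 to compound 3 (1.22 log units; beyond the scatter) and so opens a gap that the earlier aryl exchange did not show. The 4-fluorophenyl also stands clear of the 3,4-dichlorophenyl, with a 12-fold lower number from compound 1 to compound 3 (1.08 log units; beyond the scatter) at the same place. Nothing available explains this gap.

From the compounds shown here alone, whether the fluorine itself is needed remains open. The compounds shown do not tell how an unsubstituted phenyl, or a methoxy group or nitrile in its place, would read.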